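Ethyl to Isopropyl: an Untested Step on a Shared Core

This account rests on a few compounds, and the source may have more. Where it says the series, first, only, none or still open, it means among the compounds named here.

Compound 1, `Cc1n[nH]c(C(=O)O)c1Cc1ccc(C(F)(F)F)cc1`
Compound 2, `CCc1n[nH]c(C(=O)O)c1Cc1cccc(-c2ccc(F)cc2)c1`

In an assay on isolated protein for inhibition of 2-Hydroxyacid oxidase 2 (Homo sapiens), tested at 10 uM (a higher number here means a stronger effect of the compound at the concentration tested, a lower number a weaker effect), compound 1 gives 12%; compound 2 gives 36%. Compound 2 thus stands highest of the two numbers, and the gap to compound 1 lies beyond the scatter. Compound 3, `CC(C)c1n[nH]c(C(=O)O)c1Cc1cccc(-c2ccc(F)cc2)c1`, differs from compound 2 by methyl in place of hydrogen on a saturated chain carbon bound to an aromatic carbon and a saturated chain carbon. Within the data shown here, no measured pair shows this change, so its effect is unknown. The change is small, and the step of a number 2 percentage points higher from compound 2 to compound 3 (within the scatter) is expected to stay within the scatter in this assay. Compound 3 is therefore estimated at about 38%, in a range from 15% to 60%.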

Compound 3, a percentage reported as inhibition, at one concentration (the size of the read-out at that concentration, not a potency): 11%
Compound 3: middle estimate off by 27 percentage points, on the high side; measured number outside the range, below it.
By their numbers in this assay, from the lowest: compounds 3 and 1 (each within the scatter of the next); then compound 2.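

In this assay, among these compounds, the change from ethyl to isopropyl gives a number 25 percentage points lower from compound 2 to compound 3 (beyond the scatter) and is the first single-place comparison on the shared core. It shows that one added methyl on this saturated chain carbon is enough to produce a loss beyond the scatter, so this position is not indifferent to small changes. No available evidence bears on the reason for this loss.

This single step leaves open how a straight propyl chain or a cyclopropyl ring would read at this position. It also leaves open whether the same methyl would have a similar effect elsewhere on the core.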